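The source may report more compounds than this note shows. Statements on the series, on what has been measured and on what is new or still open speak of the compounds shown alone.

Measured so far:
compound 1, `O=c1[nH]c(-c2cccc3ccccc23)nc2ccc(N3CCCCC3)cc12` — 330 nM
compound 2, `Cc1ccc2c(=O)[nH]c(-c3ccccc3N(C)C)nc2c1` — 43800 nM
compound 3, `Cc1ccc2nc(-c3cccc(C(F)(F)F)c3)[nH]c(=O)c2c1` — > 50000 nM

In a functional assay on HeLa cells (Homo sapiens) for cytotoxicity, read by MTT assay, with a stated time of 2 days (on this read-out lower numbers stand for stronger inhibition and higher numbers for weaker inhibition), compound 1 gives 330 nM. Compound 2 gives 43800 nM in this assay, the highest of the two numbers shown; the value of compound 1 is far lower, well beyond the scatter. For compound 3 this assay reports only a limit, > 50000 nM; one of the three values sits at this limit (the limit of > 50000 nM in this assay, at which 1 of the 3 values shown sits).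

Compound 4, `Cc1ccc2c(=O)[nH]c(-c3ccccc3C)nc2c1`, is not yet measured in this assay. It differs from compound 2 in one place: methyl in place of dimethylamino on an aromatic carbon. For the measured compounds named here, no step between measured compounds matches this change, so the expectation rests on compound 2 alone, whose value of 43800 nM already lies near the top of the range reported in this assay. The step expected from this change is a 1.0-fold higher number from compound 2 to compound 4 (0.01 log units; within the scatter), that is, no shift beyond the scatter in either direction. Compound 4 is therefore estimated at 45000 nM in this assay, with a range from 15000 nM to 120000 nM; a reading that is only a limit is a fair possibility.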

Compound 4, half-maximal inhibitory concentration: > 50000 nM
Compound 4 ended at the assay's limit; the forecaster's own chance of this, stated with the estimate: 50%; middle value at least 1.1-fold (0.04 log units) away from the limit.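

In this assay, methyl in place of dimethylamino on an aromatic carbon, ortho to a large group, gives an at least 1.1-fold higher number from compound 2 to compound 4 (0.05 log units; that floor lies within the scatter). Compound 4 gives > 50000 nM, which is a limit of the assay and not a number. This is the first single-place change in the series, and it shows no gain from methyl at this position, while the step is only a floor that lies within the scatter and sets no upper size for the change, with the series now holding a second reading at the limit: the limit of > 50000 nM in this assay, at which 2 of the 4 values shown sit.

As far as these compounds go, the true size of this step remains open, as the reading for compound 4 gives no number. Also open, from the compounds shown here alone, is whether a primary amine, a hydroxyl or a carboxylic acid at this position would give a reading well clear of the limit.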